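Methyl in place of hydrogen on two related cores

The compounds below may be only part of what the source reports. "The series", "measured", "known", "first", "only" and "open" are said of these compounds alone.

Compound 1 `CC(c1ccccc1)c1nc2c(C(F)(F)F)cccc2c(C(=O)O)c1O` gives 50% in an assay on isolated protein for inhibition of P-selectin glycoprotein ligand 1 (Homo sapiens), read by surface plasmon resonance, tested at 250 uM; on this read-out lower numbers stand for less inhibition and higher numbers for more inhibition at the one concentration tested (going by the name of the read-out). Compound 2 `CC(C)(c1ccccc1)c1nc2c(C(F)(F)F)cccc2c(C(=O)O)c1O` gives 59% in this assay; it differs from compound 1 by methyl in place of hydrogen on a saturated chain carbon bound to two aromatic carbons and a saturated chain carbon, and the step is a number 9 percentage points higher from compound 1 to compound 2 (within the scatter). Compound 3 `Cc1cc(C(F)(F)F)c2nc(C3(c4ccccc4)CC3)c(O)c(C(=O)O)c2c1` gives 40% in this assay; the difference between its core and the core of compound 1 is not broken down here. Compound 4 `CCc1cc(C(F)(F)F)c2nc(C3(c4ccccc4)CC3)c(O)c(C(=O)O)c2c1` is not yet measured and differs from compound 3 by methyl in place of hydrogen on a saturated chain carbon bound to an aromatic carbon. This is the same kind of change as from compound 1 to compound 2, not the same: there the saturated chain carbon is bound to two aromatic carbons and a saturated chain carbon, here to an aromatic carbon. Since a number 9 percentage points higher from compound 1 to compound 2 (within the scatter) stayed within the scatter, a similarly small step is expected. The expected step is a number 6 percentage points higher from compound 3 to compound 4 (within the scatter). Compound 4 is estimated at 46%, between 30% and 62%.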

Compound 4, a percentage reported as inhibition, at one concentration (the size of the read-out at that concentration, not a potency): 40%
Estimate against measurement, compound 4: 6 percentage points above; the range from low to high includes it.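

In this assay, methyl in place of hydrogen on the core of compound 3 gives no change at the digits printed from compound 3 to compound 4 (within the scatter), and this step reads alike with the earlier one: the same change on two cores in this assay, a number 9 percentage points higher (within the scatter) from compound 1 to compound 2 and no change at the digits printed (within the scatter) from compound 3 to compound 4, 9 percentage points apart, within the scatter of two such steps. Across these two pairs, the change carries from one core to the other without a step beyond the scatter. For the compounds shown here, this does not show that the change is without effect or that it would carry to a further core; the two pairs also place the methyl on different saturated chain carbons, and each core supplies only one pair.

Open, as far as these compounds go, is what a longer chain such as propyl would give on the saturated chain carbon bound to an aromatic carbon. From the compounds shown here alone, an amine at that carbon is equally open.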